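Pentyl urea series: flipping the drawn stereocentre

The source may hold more compounds than are shown below. What is called first, only, known or untested is meant among the compounds shown, and "the series" means these compounds.

Compound 3, `CCCCCc1ccc(NC(=O)N[C@H](C)c2ccccc2)cc1`, sits at the top of three numbers in an ADME assay on the whole organism with Oryza sativa as the target, tested at 0.1 uM (on this read-out lower numbers stand for a stronger effect and higher numbers for a weaker effect at the one concentration tested), giving 100%; its nearest neighbour is compound 2, `CCCCc1ccc(NC(=O)N[C@@H](C)c2ccccc2)cc1`, which gives 98%, and the furthest is compound 1, `CCCc1ccc(NC(=O)N[C@@H](C)c2ccccc2)cc1`, with 97%, both gaps lying within the scatter. For the measured compounds named here, the only measured step, a number 1 percentage points higher from compound 1 to compound 2 (within the scatter), concerns the chain and has no bearing on a change of configuration. Compound 4, `CCCCCc1ccc(NC(=O)N[C@@H](C)c2ccccc2)cc1`, differs from compound 3 as follows: the two compounds have the same atoms and bonds and differ only in configuration as drawn: 1 of 1 stereo elements differ; a stereocentre at a saturated chain carbon is drawn R in compound 3 and S in compound 4. Going by the values given here, no step in this set speaks to such a change, so no move beyond the scatter is expected in this assay, and the expected step is a number 2 percentage points lower from compound 3 to compound 4 (within the scatter). Compound 4 is therefore estimated at 98%, within 92% to 100%.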

Compound 4, a percentage reported as activity, at one concentration (the size of the read-out at that concentration, not a potency): 98%
Compound 4: middle estimate and measured number agree at the digits printed; the range from low to high includes it.
By their numbers in this assay, from the lowest: compounds 1, 2, 4 and 3 (each within the scatter of the next).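

In this assay, the one direct test of configuration at this stereocentre gives a number 2 percentage points lower from compound 3 to compound 4 (within the scatter), so the drawn R and S forms are not told apart here, and the comparison isolates that single change: the fact that compounds 3 and 4 differ only in the configuration as drawn

With the configuration as drawn held, the chain steps give no change at the digits printed from compound 2 to compound 4 (within the scatter) and a number 1 percentage points higher from compound 1 to compound 4 (within the scatter), so adding methyl or ethyl to the chain also leaves the read-out inside the scatter.

The compounds shown leave open whether a longer chain, or an amine or a carboxylic acid in place of the chain, would move the number beyond the scatter.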